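The source may report more compounds than this note shows. Statements on the series, on what has been measured and on what is new or still open speak of the compounds shown alone.

Measured so far in an ADME assay on Vero cells (Chlorocebus sabaeus) for cytotoxicity, read by MTT assay, with a stated time of 72 h; on this read-out higher numbers stand for lower toxicity in this test and lower numbers for higher toxicity in this test:
- compound 1 `COc1c(N2CCN(CN3C(=O)C(=O)c4cc(F)ccc43)CC2)c(F)cc2c(=O)c(C(=O)O)cn(C3CC3)c12`: 70600 nM
- compound 2 `COc1c(N2CCN(CN3C(=O)/C(=N\O)c4cc(F)ccc43)CC2)c(F)cc2c(=O)c(C(=O)O)cn(C3CC3)c12`: 73800 nM

Compound 2, at 73800 nM, sits within the scatter of compound 1, at 70600 nM, so these two values cannot be ordered. For the measured compounds named here, the series therefore offers one level of response in this assay and no measured step between compounds that differ in one place.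

The next compound to be tested is compound 3 `CO/N=C1\C(=O)N(CN2CCN(c3c(F)cc4c(=O)c(C(=O)O)cn(C5CC5)c4c3OC)CC2)c2ccc(F)cc21`. It differs from compound 2 as follows: methyl in place of hydrogen on an oxygen. This is methyl in place of hydrogen on an oxygen, or hydroxy to methoxy when the same difference is cut one bond further out. Going by the values given here, no measurement yet shows what this change does in this assay, so the expectation rests only on compound 2 at 73800 nM and the closely matching compound 1 at 70600 nM.

The expected change, a 1.1-fold lower number from compound 2 to compound 3 (0.02 log units; within the scatter), stays within the scatter, with no direction favoured. For compound 3 the estimated value is 70000 nM, with an expected range from 35000 nM to 140000 nM.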

Compound 3, half-maximal cytotoxic concentration: 46800 nM
Compound 3: the middle estimate sits 1.5-fold (0.17 log units) above what was measured; the measured number falls inside the stated range.
By their numbers in this assay, from the lowest: compounds 3, 1 and 2 (each within the scatter of the next).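

In this assay, the series now has its first reading for methyl in place of hydrogen on an oxygen whose other neighbours are: double-bonded nitrogen. The result is a 1.6-fold lower number from compound 2 to compound 3 (0.20 log units; within the scatter) and shows that this hydroxy to methoxy change, with its single added carbon and the loss of the hydrogen on that oxygen, gives no resolved difference at this place in this test. No supporting data bear on how this result arises.

As far as these compounds go, the reading rests on one matched pair, so it remains open whether the same tolerance holds for larger replacements on this oxygen, such as ethyl, a longer chain, or a chain ending in an amine or a carboxylic acid. From the compounds shown here alone, it also remains open whether methyl in place of hydrogen gives a similar result at other places on the shared core, or whether a series of such replacements would produce any step beyond the scatter.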